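Notes on the aryl ring change from compound 2 to compound 4

The source may report more compounds than this note shows. Statements on the series, on what has been measured and on what is new or still open speak of the compounds shown alone.

Compound 2 `O=C(O)c1ccc(C(=O)/C(=C\c2ccc(Cl)c([N+](=O)[O-])c2)SCc2ccc(Br)cc2)cc1` stands lowest of the three numbers in a functional assay on DU-145 cells (Homo sapiens) for inhibition, read by trypan blue exclusion, with a stated time of 96 h (on this read-out lower numbers stand for stronger inhibition of growth and higher numbers for weaker inhibition of growth), with compound 2 giving 500 nM, though its nearest neighbour sits within the scatter. Compound 1 `O=C(O)c1ccc(C(=O)/C(=C\c2ccc(Br)c([N+](=O)[O-])c2)SCc2ccc(Br)cc2)cc1` gives 1000 nM, and a 2.0-fold lower number from compound 1 to compound 2 (0.30 log units; within the scatter). Compound 3 `O=C(O)c1ccc(C(=O)/C(=C\c2ccc(Cl)c([N+](=O)[O-])c2)S(=O)(=O)Cc2ccc(Br)cc2)cc1` gives 25000 nM, and a 50-fold higher number from compound 2 to compound 3 (1.70 log units; beyond the scatter).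

Compound 4 `O=C(O)c1ccc(C(=O)/C(=C\c2ccc([N+](=O)[O-])c(O)c2)SCc2ccc(Br)cc2)cc1` differs from compound 2 only on the aryl ring: 3-hydroxy-4-nitrophenyl in place of 4-chloro-3-nitrophenyl on a double-bonded chain carbon bound to a double-bonded chain carbon. For the measured compounds named here, of the measured steps, only the one from compound 1 to compound 2 touches this ring, and it was small. The large step from compound 2 to compound 3 concerns the exchange of (4-bromobenzyl)sulfanyl for (4-bromobenzyl)sulfonyl, not the ring, so it does not bear here. Going by the values given here, no measured step covers a 3-hydroxy-4-nitrophenyl group, so the change is untested. Among the compounds with values here, with the one ring step within scatter, a step of modest size at most is expected, with a hedge toward a higher number. Compound 4 is therefore expected at 1000 nM (range 300 nM to 4000 nM), meaning an expected step of a 2.0-fold higher number from compound 2 to compound 4 (0.30 log units; within the scatter).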

Compound 4, concentration for 50% growth inhibition: 10000 nM
Beside the measured number, compound 4's estimate is 10-fold (1.00 log units) below it, outside the stated range (above it).
By their numbers in this assay, from the lowest: compounds 2 and 1 (each within the scatter of the next); then compound 4; then compound 3.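

In this assay the ring on a double-bonded chain carbon bound to a double-bonded chain carbon proves sensitive to the exchange for 3-hydroxy-4-nitrophenyl, with a 20-fold higher number from compound 2 to compound 4 (1.30 log units; beyond the scatter) from 4-chloro-3-nitrophenyl and a 10-fold higher number from compound 1 to compound 4 (1.00 log units; beyond the scatter) from 4-bromo-3-nitrophenyl . The earlier step on this ring, between the chloro and bromo groups, stayed within the scatter, so these are the first ring changes shown to go beyond it, and the sulfonyl exchange is no longer the only change in the series to do so. Nothing measured alongside these compounds accounts for the size of the step.

The hydroxy group and the altered nitro placement arrive together in one exchange, and the compounds shown do not separate them. As far as these compounds go, how a methoxy group or an amine on this ring would read also remains open.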